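Fluoromethyl on a saturated ring carbon of compound 2

The compounds below may be only part of what the source reports. "The series", "measured", "known", "first", "only" and "open" are said of these compounds alone.

In an ADME assay on microsomes from liver (Homo sapiens) for metabolic stability (on this read-out higher numbers stand for fast clearance and lower numbers for slow clearance), compound 1 `C[C@@]1(c2cc(NC(=O)c3cnc(OCF)cn3)ccc2F)CCC(F)(F)C(N)=N1` gives 10.1 mL.min-1.g-1 and compound 2 `NC1=N[C@@]2(c3cc(NC(=O)c4cnc(OCF)cn4)ccc3F)COCC[C@H]2CC1(F)F` gives 46.2 mL.min-1.g-1 while compound 3 `C[C@H]1C[C@H]2CC(F)(F)C(N)=N[C@@]2(c2cc(NC(=O)c3cnc(OCF)cn3)ccc2F)CO1` gives 119 mL.min-1.g-1 as its number, which leaves compound 2 in the middle of the three. Compound 4 `NC1=N[C@@]2(c3cc(NC(=O)c4cnc(OCF)cn4)ccc3F)CO[C@@H](CF)C[C@H]2CC1(F)F` differs from compound 2 by fluoromethyl in place of hydrogen on a saturated ring carbon next to the ring oxygen (fluoromethyl in place of hydrogen on a saturated ring carbon). The closest measured guide is the modest 2.6-fold higher number from compound 2 to compound 3 (0.41 log units; beyond the scatter) for methyl in place of hydrogen on a saturated ring carbon. Fluoromethyl is a different group, so the size stays uncertain, but a rise of similar size is expected, and the estimated change is a 1.9-fold higher number from compound 2 to compound 4 (0.29 log units; within the scatter) in that direction. In this assay the estimate for compound 4 is 90 mL.min-1.g-1 within an expected range from 40 mL.min-1.g-1 to 190 mL.min-1.g-1 overall.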

Compound 4, intrinsic clearance in microsomes: 24.9 mL.min-1.g-1
Compound 4: the middle estimate sits 3.6-fold (0.56 log units) above what was measured, and the stated range ends above it.
By their numbers in this assay, from the lowest: compound 1; then compounds 4 and 2 (each within the scatter of the next); then compound 3.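

In this assay, fluoromethyl on this saturated ring carbon next to the ring oxygen gives a 1.9-fold lower number from compound 2 to compound 4 (0.27 log units; within the scatter), a step within the usual scatter, whereas methyl here gave a 2.6-fold higher number from compound 2 to compound 3 (0.41 log units; beyond the scatter), beyond it. With methyl as the reference, adding fluoro to that saturated chain carbon gives a 4.8-fold lower number from compound 3 to compound 4 (0.68 log units; beyond the scatter), so this single replacement of hydrogen separates the two substituted compounds by more than the scatter. No measurement shown explains this difference.

Going by these compounds, how a hydroxymethyl or an aminomethyl group on this same carbon would read remains open.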